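The source may hold more compounds than are shown below. What is called first, only, known or untested is meant among the compounds shown, and "the series" means these compounds.

Measured compounds:
- compound 1 `CCC1=C(O)c2c(oc(-c3ccc(C(F)(F)F)cc3)cc2=O)C(CC)(CC)C1=O`: 10.4 uM
- compound 2 `CCC1=C(O)c2c(oc(-c3cccc(C)c3)cc2=O)C(CC)(CC)C1=O`: 3.69 uM
- compound 3 `CCC1=C(O)c2c(oc(-c3cc(OC)cc(OC)c3)cc2=O)C(CC)(CC)C1=O`: 3.27 uM

All three numbers come from a functional assay on KBVIN cells (Homo sapiens) for antiproliferative activity, read by sulforhodamine B assay, with a stated time of 3 days; a lower number here means that less compound is needed, a higher number that more compound is needed for the effect. Compound 2 holds the second highest of the three numbers. Its nearest neighbour is compound 3, whose value sits within the scatter of that of compound 2, so no order between these two can be read from the data. Within the data shown here, compound 1 stands furthest away, with a higher number than compound 2, and that gap lies beyond the scatter; it is the one compound of the three whose aryl group carries a trifluoromethyl substituent.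

The step under consideration leads from compound 2 to compound 4 `CCC1=C(O)c2c(oc(-c3cc(C)ccc3F)cc2=O)C(CC)(CC)C1=O`, which has not yet been measured in this assay. The change is fluoro in place of hydrogen on an aromatic carbon. Among the measured compounds shown here, no measured pair shows this kind of change, so there is no direct precedent to lean on. The expectation is a step of a 1.1-fold lower number from compound 2 to compound 4 (0.02 log units; within the scatter), that is, no movement beyond the scatter in either direction. For compound 4 the estimated value in this assay is 3.5 uM, with a range from 1.5 uM to 8 uM.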

Compound 4, concentration for half-maximal effect: 3.24 uM
The estimate for compound 4 lay 1.1-fold (0.03 log units) above the measured number; low and high end bracket the measured number.
By their numbers in this assay, from the lowest: compounds 4, 3 and 2 (each within the scatter of the next); then compound 1.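

In this assay, fluoro in place of hydrogen on the aromatic carbon ortho to a large group and para to the methyl group gives a 1.1-fold lower number from compound 2 to compound 4 (0.06 log units; within the scatter), so no effect of this change at this position can be read. Among these compounds, this is the only pair that differs in one place, and it gives the first direct reading of a single change on the aryl group, which the earlier compounds could not provide. No supporting measurement is available to interpret this result.

From the compounds shown here alone, it remains open whether fluoro at this position would behave in the same way on the aryl groups of compound 1 and compound 3. Also open, going by these compounds, is what chloro, methoxy or an amine would do at this position, and what a carboxylic acid would do in place of the methyl group.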